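The source may report more compounds than this note shows. Statements on the series, on what has been measured and on what is new or still open speak of the compounds shown alone.

Compound 3 `CCCOC(=O)C1=C(C)N(C)C(=O)NC1c1ccco1` stands lowest of the three compounds measured in an assay on membranes from CHO cells for displacement of a labelled ligand from adenosine receptor A1 (Homo sapiens), read by scintillation counting, with a stated time of 60 min, tested at 1 uM; on this read-out higher numbers stand for more inhibition at the one concentration tested (going by the name of the read-out) and lower numbers for less inhibition. In this assay compound 3 gives 3%, while compound 1 `COC(=O)C1=C(C)NC(=S)NC1c1ccoc1` gives 25% and compound 2 `COC(=O)C1=C(C)N(C)C(=O)NC1c1ccco1` gives 45%. For the measured compounds named here, the one measured step that changes a single place is a number 42 percentage points lower from compound 2 to compound 3 (beyond the scatter), where the ester chain grows from methyl to propyl; it moved the number well beyond the scatter and downward.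

Compound 4 `CC1=C(C(=O)OCC(C)C)C(c2ccco2)NC(=O)N1C` differs from compound 3 by methyl in place of hydrogen on a saturated chain carbon bound to two saturated chain carbons. Going by the values given here, this change lengthens the same ester chain once more, so the step from compound 2 to compound 3 is the only measured evidence bearing on it. That step was a large drop, and compound 3 already sits near the bottom of the scale, so a further fall of any size is hardly possible. The expectation is therefore a small downward step or none beyond the scatter, no change at the digits printed from compound 3 to compound 4 (within the scatter), and compound 4 is estimated to give 3%, between 0% and 18%.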

Compound 4, a percentage reported as inhibition, at one concentration (the size of the read-out at that concentration, not a potency): 13%
Estimate against measurement, compound 4: 10 percentage points below; the measured number falls inside the stated range.
By their numbers in this assay, from the lowest: compounds 3 and 4 (each within the scatter of the next); then compound 1; then compound 2.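

The methyl that turns propyl into isobutyl gives a number 10 percentage points higher from compound 3 to compound 4 (within the scatter) in this assay so at this place on the ester chain, the branched chain and the straight chain cannot be told apart. The drop from the methyl ester now has a second example, a number 32 percentage points lower from compound 2 to compound 4 (beyond the scatter) so it is not peculiar to propyl: both chains shown here that are longer than methyl go with low numbers. No supporting information is available to explain this pattern.

From the compounds shown here alone, what remains open is where the fall begins and whether it holds for other groups: an ethyl ester, a longer chain such as butyl, or a benzyl ester could each test this. A carboxylic acid or an amide made from an amine in place of the ester would show whether the ester itself is needed.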